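This account rests on a few compounds, and the source may have more. Where it says the series, first, only, none or still open, it means among the compounds named here.

Among the measured compounds shown here, compound 2 `O=S(=O)(c1ccc(Cl)cc1)c1cn(C2CCCNC2)c2ncccc12` is the weaker of the two sulfonyl aryl analogues measured in an assay on HeLa cells for displacement of a labelled ligand from 5-hydroxytryptamine receptor 6 (Homo sapiens); on this read-out lower numbers stand for stronger inhibition and higher numbers for weaker inhibition: compound 2 gives 7.6 nM, whereas compound 1 `O=S(=O)(c1cccc(Cl)c1)c1cn(C2CCCNC2)c2ncccc12` gives 1.3 nM, the one measured step being a 5.8-fold higher number from compound 1 to compound 2 (0.77 log units; beyond the scatter). Compound 3 `O=S(=O)(c1ccccc1F)c1cn(C2CCCNC2)c2ncccc12` differs from compound 2 by 2-fluorophenyl in place of 4-chlorophenyl on a sulfonyl sulfur. For the measured compounds named here, the only step on record, from compound 1 to compound 2, shows that changing the substitution of this phenyl ring moves this assay by a modest amount; both the halogen and its place now change at once, so the direction is not fixed by the data. A modest change back toward compound 1 is the working expectation, with the estimated step being a 2.5-fold lower number from compound 2 to compound 3 (0.40 log units; beyond the scatter). Compound 3 is thus estimated at 3 nM, within a range of 0.7 nM to 13 nM.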

Compound 3, inhibition constant: 2 nM
Estimate against measurement, compound 3: 1.5-fold (0.18 log units) above; low and high end bracket the measured number.
By their numbers in this assay, from the lowest: compounds 1 and 3 (each within the scatter of the next); then compound 2.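

In this assay, chlorine on the aryl ring at the sulfonyl sulfur is not required for a low number: 2-fluorophenyl gives a 3.8-fold lower number from compound 2 to compound 3 (0.58 log units; beyond the scatter) and, with a 1.5-fold higher number from compound 1 to compound 3 (0.19 log units; within the scatter), it cannot be told apart from 3-chlorophenyl. Of the three aryl groups, only 4-chlorophenyl stands apart. No measured evidence accounts for this difference.

Halogen and its place change together between these compounds, so their separate contributions remain unresolved. On these data alone, whether an amine or a carboxylic acid on this phenyl ring would keep the number this low also stays open.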